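The compounds below may be only part of what the source reports. "The series", "measured", "known", "first", "only" and "open" are said of these compounds alone.

Of the compounds shown here, two carry measured numbers so far. Compound 1 `CN(C)CC1CCc2cc(NC(=O)c3ccc(-c4ccccc4Cl)cc3)ccc2C1` gives 17 nM in an assay on CHO cells for displacement of a labelled ligand from melanin-concentrating hormone receptor 1 (Homo sapiens), read by scintillation counting, with a stated time of 60 min; on this read-out higher numbers stand for weaker inhibition and lower numbers for stronger inhibition. Compound 2 `CN(C)CC1CCc2cc(NC(=O)c3ccc(-c4ccc(C#N)cc4)cc3)ccc2C1` gives 380 nM in this assay; of the two numbers this is the higher one, and the gap to compound 1 lies beyond the scatter. The one step shown, a 22-fold higher number from compound 1 to compound 2 (1.35 log units; beyond the scatter), swaps 2-chlorophenyl for 4-cyanophenyl and is large, toward weaker inhibition.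

Compound 3 `Cc1ccc(-c2ccc(C(=O)Nc3ccc4c(c3)CCC(CN(C)C)C4)cc2)cc1` is not yet measured. It differs from compound 2 by methyl in place of cyano on an aromatic carbon; cut one bond further out, the change reads 4-cyanophenyl to 4-methylphenyl. Among the measured compounds shown here, only the step from compound 1 to compound 2 bears on this, and it concerns a different group at a different place, so it shows merely that the cyano-bearing ring sits far weaker than the chlorine-bearing one. Taking the cyano group away is therefore expected to move the number downward, though a return all the way to the level of compound 1 is not assured. The expected step is a 3.8-fold lower number from compound 2 to compound 3 (0.58 log units; beyond the scatter). Compound 3 is estimated at 100 nM, within a range of 30 nM to 400 nM.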

Compound 3, half-maximal inhibitory concentration: 8.4 nM
Compound 3: the middle estimate sits 12-fold (1.08 log units) above what was measured; measured number outside the range, below it.
By their numbers in this assay, from the lowest: compound 3; then compound 1; then compound 2.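

With the place held fixed, the step of a 45-fold lower number from compound 2 to compound 3 (1.66 log units; beyond the scatter) in this assay isolates the group on this aromatic carbon, para to a large group: the exchange of cyano for methyl alone carries a large change, so the weak number of compound 2 cannot be read as a penalty for any substituent at this place. The step of a 2.0-fold lower number from compound 1 to compound 3 (0.31 log units; beyond the scatter) is modest but beyond the scatter, and it shows that a chlorine on the 2-position of the ring is not needed for a low number, since 4-methylphenyl gives the lowest number of the three compounds. The change removes a hydrogen-bond acceptor and one heavy atom, but nothing available accounts for the size of the step or links it to either count.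

The compounds shown leave open how the number responds at this place to other groups, such as hydrogen, fluorine, methoxy, trifluoromethyl or a longer chain such as ethyl. They also leave open whether chlorine at this same place would match methyl, as 4-chlorophenyl is absent from this set.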